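Removing One Trifluoromethyl Group: What to Expect

The source may report more compounds than this note shows. Statements on the series, on what has been measured and on what is new or still open speak of the compounds shown alone.

Of the compounds shown here, three built on a shared core have been measured in a functional assay on OVCAR-4 cells (Homo sapiens) for inhibition, read by sulforhodamine B assay, with a stated time of 48 h, tested at 0.01 uM; on this read-out lower numbers stand for a stronger effect and higher numbers for a weaker effect at the one concentration tested. Compound 1 `O=C(Nc1cccc(-n2cc(-c3ccncc3)c(-c3cc(O)cc(Cl)c3)n2)c1)Nc1ccc(Cl)c(C(F)(F)F)c1` gives 99% in this assay. Compound 2 `O=C(Nc1cccc(-n2cc(-c3ccncc3)c(-c3cc(O)cc(Cl)c3)n2)c1)Nc1ccc(Cl)c(Cl)c1` gives 108% in this assay. The step between them, a chloro in place of a trifluoromethyl on an aromatic carbon, is a number 9 percentage points higher from compound 1 to compound 2 (within the scatter). Compound 3 `COc1cc(Cl)cc(-c2nn(-c3cccc(NC(=O)Nc4cc(C(F)(F)F)cc(C(F)(F)F)c4)c3)cc2-c2ccncc2)c1` gives 93% in this assay, the lowest of the three numbers; its gap to compound 1 lies within the scatter, and only its gap to compound 2 lies beyond it.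

Compound 4 `COc1cc(Cl)cc(-c2nn(-c3cccc(NC(=O)Nc4cccc(C(F)(F)F)c4)c3)cc2-c2ccncc2)c1` has not yet been measured. It differs from compound 3 in one place: hydrogen in place of trifluoromethyl on an aromatic carbon. Among the measured compounds shown here, the only measured step that touches a trifluoromethyl group on that ring is a number 9 percentage points higher from compound 1 to compound 2 (within the scatter), which stays within the scatter. For the measured compounds named here, no measured step removes a trifluoromethyl group outright, so the data offer no direct guide for this change. The step is therefore expected to be small, about a number 7 percentage points higher from compound 3 to compound 4 (within the scatter), not clearly beyond the scatter in either direction. Compound 4 is expected to give about 100% in this assay, with a likely range from 85% to 115%.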

Compound 4, a percentage reported as activity, at one concentration (the size of the read-out at that concentration, not a potency): 93%
Beside the measured number, compound 4's estimate is 7 percentage points above it; low and high end bracket the measured number.
By their numbers in this assay, from the lowest: compounds 3, 4, 1 and 2 (each within the scatter of the next, the first and the last beyond it).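

In this assay, removing one of the two trifluoromethyl groups from the aromatic ring, a loss of 4 heavy atoms, gives no change at the digits printed from compound 3 to compound 4 (within the scatter), the first measured case of this group being replaced by plain hydrogen rather than by another substituent. At this place, on an aromatic carbon meta to a large group and meta to a trifluoromethyl group, the read-out at the one concentration tested therefore does not register the loss, although a single concentration is not a potency and cannot exclude a difference that would appear at other concentrations. The data shown contain no independent measurement that could explain this result.

The compounds shown leave open whether a different group at this place, such as an amine, a carboxylic acid or a longer chain, would move the number beyond the scatter. They also leave open whether removing the remaining trifluoromethyl group as well would read the same, and whether the same change would behave alike at other concentrations.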